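A Single Substituent Swap on a Ring Amide Nitrogen

The source may report more compounds than this note shows. Statements on the series, on what has been measured and on what is new or still open speak of the compounds shown alone.

Compound 1 `CC(C)N1C(=O)COc2ccc(-c3cccc(NS(=O)(=O)c4ccc(F)cc4)c3)cc21`: > 40000 nM, a limit of the assay.
Compound 2 `O=C1COc2ccc(-c3cccc(NS(=O)(=O)c4ccc(F)cc4)c3)cc2N1c1ccc(Cl)cc1`: 32500 nM.
Compound 3 `COc1ncc(-c2ccc3c(c2)N(c2ccc(Cl)cc2)C(=O)CO3)cc1NS(=O)(=O)c1ccc(F)cc1`: 24100 nM.

All three compounds were tested in a functional assay on A-375 cells (Homo sapiens) for antiproliferative activity, read by MTT assay, with a stated time of 72 h; a lower number here means a stronger inhibitor, a higher number a weaker inhibitor. Compound 2 gives 32500 nM there, and compound 3 gives 24100 nM; these two values lie within the scatter of each other, so neither can be called stronger than the other. The difference between the core of compound 2 and the core of compound 3 is not broken down here. For compound 1 the assay reports only a limit, > 40000 nM, and not a number.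

Within the data shown here, the one measured step concerns the change (isopropyl in place of 4-chlorophenyl on an amide-type nitrogen in a ring), which gave an at least 1.2-fold higher number from compound 2 to compound 1 (0.09 log units; that floor lies within the scatter). Its size is known only as a floor because the limit of > 40000 nM in this assay, at which 1 of the 3 values shown sits, applies to compound 1.

Compound 4 `COc1ncc(-c2ccc3c(c2)N(C(C)C)C(=O)CO3)cc1NS(=O)(=O)c1ccc(F)cc1` is not yet measured. It arises from compound 3 by isopropyl in place of 4-chlorophenyl on an amide-type nitrogen in a ring, the same change as that from compound 2 to compound 1, at the same place. On the strength of the measured step of an at least 1.2-fold higher number from compound 2 to compound 1 (0.09 log units; that floor lies within the scatter), the account expects a weakening of similar or greater size, a 1.9-fold higher number from compound 3 to compound 4 (0.27 log units; within the scatter), for compound 4. Compound 4 is therefore estimated at 45000 nM in this assay, with a likely range from 22000 nM to 95000 nM, and a real chance that only a limit is returned.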

Compound 4, half-maximal inhibitory concentration: 9950 nM
Compound 4: middle estimate off by 4.5-fold (0.66 log units), on the high side; measured number outside the range, below it.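

In this assay, putting isopropyl in place of 4-chlorophenyl on the amide-type nitrogen in the ring gave a 2.4-fold lower number from compound 3 to compound 4 (0.38 log units; beyond the scatter), a modest gain on this core. The same change therefore does not carry a fixed effect from the core of compound 2 to the core of compound 3, and the two steps differ by more than repeated measurements would explain: the same change on two cores in this assay, an at least 1.2-fold higher number (0.09 log units; that floor lies within the scatter) from compound 2 to compound 1 and a 2.4-fold lower number (0.38 log units; beyond the scatter) from compound 3 to compound 4, at least 2.9-fold (0.47 log units) apart, beyond the scatter of two such steps This comparison rests on two cores only, so it gives no general rule for other cores and no reason for the gap, and the full size of the earlier step stays unknown, as the value for compound 1 is only a limit of the assay: the limit of > 40000 nM in this assay, at which 1 of the 4 values shown sits.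

The compounds shown leave open which part of the difference between the two cores goes with this gap, including whether the methoxy group alone is enough. They also leave open how the core of compound 3 would respond to other groups on the same nitrogen, such as a cyclopropyl group, a longer chain or a chain ending in an amine.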